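Fluoro removal on two different rings in one lymphocyte series

A few compounds are considered here, and "the series" means these few. Any claim that something is new, unique, unknown or untested is made for them only; others in the source may bear on it.

Measured so far:
compound 1 `Nc1nc(N2CCN(C(=O)COc3ccccc3)CC2)c2ccsc2n1`, 780 nM
compound 2 `Nc1nc(N2CCN(C(=O)COc3ccc(F)cc3)CC2)c2ccsc2n1`, 66 nM
compound 3 `Cc1cccc(NC(=O)N2CCN(c3nc(N)nc4sc(F)cc34)CC2)c1`, 2800 nM

In a functional assay on cells (Lymphocyte) (a higher number here means a weaker inhibitor, a lower number a stronger inhibitor), compound 2 gives 66 nM, and compound 1 gives 780 nM. The change between them, (hydrogen in place of fluoro on an aromatic carbon), made a large step: a 12-fold higher number from compound 2 to compound 1 (1.07 log units; beyond the scatter). Compound 3 gives 2800 nM, the highest number of the three. The difference between the cores of compound 3 and compound 2 is not broken down here.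

Compound 4 `Cc1cccc(NC(=O)N2CCN(c3nc(N)nc4sccc34)CC2)c1` is not yet measured. It differs from compound 3 by hydrogen in place of fluoro on an aromatic carbon. This is the same kind of change as from compound 2 to compound 1, but not the same: there the fluoro sat on a six-membered aromatic ring of carbon only, para to a large group; here it sits on a five-membered aromatic ring with one sulfur, part of a fused system of two rings, next to the ring sulfur. The earlier step rests on one pair only and on a different place, so a step of the same size is not assumed. For compound 4 the expected step is a 1.3-fold higher number from compound 3 to compound 4 (0.10 log units; within the scatter), a modest weakening, resting on the direction seen in a 12-fold higher number from compound 2 to compound 1 (1.07 log units; beyond the scatter). Compound 4 is expected to give 3500 nM in this assay, between 1000 nM and 12000 nM.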

Compound 4, half-maximal inhibitory concentration: 930 nM
Compound 4: middle estimate off by 3.8-fold (0.58 log units), on the high side, and the stated range ends above it.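

Hydrogen in place of fluoro on the five-membered aromatic ring gives a 3.0-fold lower number from compound 3 to compound 4 (0.48 log units; beyond the scatter) in this assay and so does not carry over in direction or size from the other core: the same change on two cores in this assay, a 12-fold higher number (1.07 log units; beyond the scatter) from compound 2 to compound 1 and a 3.0-fold lower number (0.48 log units; beyond the scatter) from compound 3 to compound 4, 36-fold (1.55 log units) apart, beyond the scatter of two such steps.
This rests on one pair per core, and the fluoro sits on a different ring in each pair, so the effects of core and place cannot be separated.
Without fluoro, (3-methylphenyl)amino in place of phenoxymethyl gives a 1.2-fold higher number from compound 1 to compound 4 (0.08 log units; within the scatter) while the same group in place of (4-fluorophenoxy)methyl gives a 14-fold higher number from compound 2 to compound 4 (1.15 log units; beyond the scatter) and the gain from the fluoro on the phenoxy ring stands on compound 2 alone.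

Open, going by these compounds, is how that fluoro would read on the core of compound 3. Also open, on these data alone, is how a chloro group or a nitrile would read on the five-membered aromatic ring.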